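The compounds below may be only part of what the source reports. "The series", "measured", "known", "first", "only" and "open" are said of these compounds alone.

Measured so far:
- compound 1 `COc1ccc(-c2cc3ccccc3nc2/C=C/C(=O)c2ccccc2)cc1`: 7410 nM
- compound 2 `COc1ccc(-c2cc3ccccc3nc2/C=C/C(=O)c2ccsc2)cc1`: 8210 nM

Both numbers come from a functional assay on A549 cells (Homo sapiens) for antiproliferative activity, read by XTT assay, with a stated time of 72 h; a lower number here means a stronger inhibitor, a higher number a weaker inhibitor. The number for compound 1 and the number for compound 2 lie within the scatter of each other, so neither can be called the stronger inhibitor. Compound 3 `COc1ccc(-c2cc3ccccc3nc2/C=C/C(=O)c2ccc[nH]2)cc1` is not yet measured. It differs from compound 1 in one place: 1H-pyrrol-2-yl in place of phenyl on a carbonyl carbon. Among the measured compounds shown here, the only measured step that bears on this change is the one from compound 1 to compound 2, where a thiophen-3-yl also replaced the phenyl on the carbonyl carbon, giving a 1.1-fold higher number from compound 1 to compound 2 (0.04 log units; within the scatter). That step stayed within the scatter, and the change to compound 3 again puts a five-membered aromatic ring with one hetero atom in the same place, so no step beyond the scatter is expected in this assay. Compound 3 is therefore estimated at 8000 nM, between 3500 nM and 18000 nM, an expected step of a 1.1-fold higher number from compound 1 to compound 3 (0.03 log units; within the scatter).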

Compound 3, half-maximal inhibitory concentration: > 10000 nM
Compound 3 ended at the assay's limit; the forecaster's own chance of this, stated with the estimate: 5%; middle value at least 1.2-fold (0.09 log units) away from the limit.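

In this assay, compound 3 gives > 10000 nM, which is a limit of the assay and not a number. Read as floors, the change to 1H-pyrrol-2-yl, the first group here on the carbonyl carbon with a hydrogen-bond donor, gives an at least 1.3-fold higher number from compound 1 to compound 3 (0.13 log units; that floor lies within the scatter), and an at least 1.2-fold higher number from compound 2 to compound 3 (0.08 log units; that floor lies within the scatter). Unlike thiophen-3-yl in compound 2, this group therefore gives a reading with no upper end, so the true step may be small or large.

The compounds shown leave open whether the hydrogen on the ring nitrogen matters at all, and whether any group on this carbonyl carbon can move the number clearly away from those of compound 1 and compound 2. A pyrrole ring with a methyl group on its nitrogen, or a furan ring, would speak to the first question.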